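A few compounds are considered here, and "the series" means these few. Any claim that something is new, unique, unknown or untested is made for them only; others in the source may bear on it.

Measured compounds: compound 1 `COc1ccccc1-c1nnc(-c2ccc(C(=O)N/N=C/c3cc(O)ccc3O)cc2)o1` with 100000 nM, compound 2 `COc1ccccc1-c1nnc(-c2ccc(C(=O)N/N=C/c3cccc(F)c3)cc2)o1` with 353000 nM, compound 3 `COc1ccccc1-c1nnc(-c2ccc(C(=O)N/N=C/c3ccc(Cl)cc3Cl)cc2)o1` with 78800 nM, all in an ADME assay on THP-1 cells (Homo sapiens) for cytotoxicity; a higher number here means a weaker inhibitor, a lower number a stronger inhibitor.

Compound 3 gives the lowest of the three numbers in this assay, yet compound 1 sits closest to it, and that gap is within the scatter; only compound 2 stands apart, as a 4.5-fold lower number from compound 2 to compound 3 (0.65 log units; beyond the scatter) shows.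

Compound 4 `COc1ccccc1-c1nnc(-c2ccc(C(=O)N/N=C/c3ccc(O)cc3O)cc2)o1` arises from compound 3 by 2,4-dihydroxyphenyl in place of 2,4-dichlorophenyl on a carbon with a double bond to nitrogen. For the measured compounds named here, the one measured step that bears on this change is a 1.3-fold lower number from compound 1 to compound 3 (0.10 log units; within the scatter), a swap between a dichlorophenyl and a dihydroxyphenyl that stayed within the scatter. On that basis no step beyond the scatter is expected in this assay for compound 4, in either direction.

Compound 4 is therefore estimated at 90000 nM, within 35000 nM to 230000 nM, a step of a 1.1-fold higher number from compound 3 to compound 4 (0.06 log units; within the scatter).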

Compound 4, half-maximal inhibitory concentration: 104000 nM
Compound 4: middle estimate off by 1.2-fold (0.06 log units), on the low side, and the stated range covers the measured number.
By their numbers in this assay, from the lowest: compounds 3, 1 and 4 (each within the scatter of the next); then compound 2.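

In this assay, the two hydroxyl groups can be arranged as 2,5-dihydroxyphenyl or 2,4-dihydroxyphenyl with no readable difference (a 1.0-fold higher number from compound 1 to compound 4 (0.02 log units; within the scatter)). Replacing 2,4-dichlorophenyl with 2,4-dihydroxyphenyl also stays within the scatter (a 1.3-fold higher number from compound 3 to compound 4 (0.12 log units; within the scatter)), while 3-fluorophenyl remains apart from this second dihydroxyphenyl compound too (a 3.4-fold lower number from compound 2 to compound 4 (0.53 log units; beyond the scatter)). No measurement offered here explains these results. On these data alone, it remains open whether an aminophenyl or a carboxyphenyl on the same carbon would group with compound 1, compound 3 and compound 4 or with compound 2.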